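The source may hold more compounds than are shown below. What is called first, only, known or untested is meant among the compounds shown, and "the series" means these compounds.

Compound 1 `Cc1noc(C)c1-c1ccc2c(c1)c(Cc1ccc(F)cc1)cn2CCCCCC(=O)NO`: 15500 nM
Compound 2 `Cc1ccccc1Cc1cn(CCCCCC(=O)NO)c2ccc(-c3c(C)noc3C)cc12`: 15500 nM
Compound 3 `Cc1cccc(Cc2cn(CCCCCC(=O)NO)c3ccc(-c4c(C)noc4C)cc23)c1`: 15500 nM
Compound 4 `Cc1ccc(Cc2cn(CCCCCC(=O)NO)c3ccc(-c4c(C)noc4C)cc23)cc1`: not yet measured

In a functional assay on THP-1 cells (Homo sapiens) for inhibition (on this read-out higher numbers stand for weaker inhibition of growth and lower numbers for stronger inhibition of growth), compound 3 gives 15500 nM, level with the other two measured compounds at the digits shown.

Compound 4 differs from compound 3 in one place: 4-methylphenyl in place of 3-methylphenyl on a saturated chain carbon bound to an aromatic carbon. This puts 4-methylphenyl in place of 3-methylphenyl on a saturated chain carbon bound to an aromatic carbon, and the same change can be read as 3-methylbenzyl to 4-methylbenzyl.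

Three measured steps alter the group at this same place. With 2-methylphenyl in place of 4-fluorophenyl there is no change at the digits printed from compound 1 to compound 2 (within the scatter). With 3-methylphenyl in place of 4-fluorophenyl there is no change at the digits printed from compound 1 to compound 3 (within the scatter). With 3-methylphenyl in place of 2-methylphenyl there is no change at the digits printed from compound 2 to compound 3 (within the scatter). None of these steps goes beyond the scatter, so no step beyond the scatter is expected in this assay, and neither direction is favoured. Among the compounds with values here, with only three measured compounds, this remains a modest basis for prediction.

The expected step is no change at the digits printed from compound 3 to compound 4 (within the scatter). The estimated value for compound 4 is 15500 nM, with an expected range of 10000 nM to 21000 nM.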

Compound 4, concentration for 50% growth inhibition: 15500 nM
Compound 4: middle estimate and measured number agree at the digits printed; measured number inside the range.
By their numbers in this assay, from the lowest: compounds 1, 2, 3 and 4 (each within the scatter of the next).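

In this assay, the new compound completes the set of 2-methylphenyl, 3-methylphenyl and 4-methylphenyl, and moving the methyl to the 4-methylphenyl arrangement gives no change at the digits printed from compound 3 to compound 4 (within the scatter) and also no change at the digits printed from compound 2 to compound 4 (within the scatter), so within these compounds, where the methyl sits on the phenyl ring makes no visible difference to the read-out. Within the data shown here, compound 4 also gives the first clean exchange of one substituent at a matching ring place, since methyl in place of fluoro on an aromatic carbon gives no change at the digits printed from compound 1 to compound 4 (within the scatter), whereas the earlier steps changed the substituent and its ring place together. No measurement shown offers an explanation for this uniform result.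

All four compounds give one identical number, so this set cannot show which changes at this place, if any, would shift growth inhibition in either direction. As far as these compounds go, it remains open whether a carboxylic acid or an amine in place of the methyl, or a longer chain in place of the benzyl group, would separate from these compounds, and whether the same insensitivity would hold with a different core.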